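The source may report more compounds than this note shows. Statements on the series, on what has been measured and on what is new or still open speak of the compounds shown alone.

Measured compounds:
- compound 1 `Cc1nn2ccccc2c1C(=O)NCc1ccc(N2CCC(c3ccc(OC(F)(F)F)cc3)CC2)cc1` — an ADME assay on Vero cells (Chlorocebus sabaeus) for cytotoxicity, read by CCK-8 assay, with a stated time of 72 h; on this read-out higher numbers stand for weaker inhibition and lower numbers for stronger inhibition: > 100000 nM
- compound 2 `CCc1ccn2nc(C)c(C(=O)NCc3ccc(N4CCC(c5ccc(OC(F)(F)F)cc5)CC4)cc3)c2c1` — this assay: > 100000 nM
- compound 3 `O=C(NCc1ccc(N2CCC(c3ccc(OC(F)(F)F)cc3)CC2)cc1)c1cnn2ccc(Cl)cc12` — this assay: "not determined" (no result reported)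

In this assay compound 1 gives only a limit, > 100000 nM. Compound 2 likewise gives only a limit, > 100000 nM. The step from compound 1 to compound 2, a step that the two limits leave unreadable from compound 1 to compound 2, is therefore not readable; the change is ethyl in place of hydrogen on an aromatic carbon. For compound 3 no result is reported in this assay.

Compound 4 `CCc1nn2ccc(Cl)cc2c1C(=O)NCc1ccc(N2CCC(c3ccc(OC(F)(F)F)cc3)CC2)cc1` is the unmeasured member. It differs from compound 3 by ethyl in place of hydrogen on an aromatic carbon. This is the same kind of change as that from compound 1 to compound 2, but it does not sit at the same place, as the two descriptions of the change show. The two cores differ by a group of 10 heavy atoms (7 carbon, 2 nitrogen, 1 chlorine; one five-membered aromatic ring with 2 hetero atoms, one six-membered aromatic ring with 1 hetero atom) in place of a group of 10 heavy atoms (8 carbon, 2 nitrogen; one five-membered aromatic ring with 2 hetero atoms, one six-membered aromatic ring with 1 hetero atom), on a carbonyl carbon.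

For the measured compounds named here, the only evidence in this assay is the limit of > 100000 nM in this assay, at which 2 of the 3 values shown sit, where both measured values sit. Going by the values given here, no size of step from compound 3 to compound 4 can be read, and a limit rather than a number is expected again. Compound 4 is expected to give about 100000 nM, with the range 50000 nM to 300000 nM.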

Compound 4, half-maximal inhibitory concentration: > 100000 nM
Compound 4 gave a limit, no number; the forecaster's own chance of this, stated with the estimate: 80%; the middle value lies on the limit itself.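

In this assay compound 4 gives > 100000 nM, a limit and not a number. No new step can be read: the steps linking compound 4 with compound 1 and compound 2 join limits only, and compound 3 offers no value to set against compound 4. The compounds shown leave open whether ethyl in place of hydrogen on an aromatic carbon changes the read-out at all, and at what concentration any of them would reach half-maximal inhibition.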